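The source may report more compounds than this note shows. Statements on the series, on what has been measured and on what is new or still open speak of the compounds shown alone.

Compound 1 `C[Se]/C(=N\C(=O)c1cc2ccccc2s1)NC(=O)c1cc2ccccc2s1` gives > 100000 nM in a functional assay on HT-29 cells (Homo sapiens) for cytotoxicity, read by MTT assay, with a stated time of 72 h (a lower number here means a stronger inhibitor of growth, a higher number a weaker inhibitor of growth), which is a limit of the assay and not a number.
Compound 2 `CS/C(=N\C(=O)c1cccs1)NC(=O)c1cccs1` gives > 100000 nM in this assay, again a limit.

Compound 1 therefore stands at the limit of > 100000 nM in this assay, at which 2 of the 2 values shown sit, so only its weakness is known, not a true value. Compound 3 `O=C(/N=C(/NC(=O)c1cc2ccccc2s1)[Se]Cc1ccccc1)c1cc2ccccc2s1` differs from compound 1 by phenyl in place of hydrogen on a saturated chain carbon bound to a selenium atom. Going by the values given here, no two measured compounds differ by a change of this kind, so nothing here sets the size of such a step. The step from compound 1 to compound 3 is expected to be a number no higher from compound 1 to compound 3 (the limit leaves the size open), that is, none beyond the usual scatter. Compound 3 is estimated at 100000 nM, most likely between 30000 nM and 300000 nM.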

Compound 3, concentration for total growth inhibition: > 100000 nM
Compound 3 was reported as a limit; the forecaster's own chance of this, stated with the estimate: 80%; the middle value sits exactly at the limit.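

Going by these compounds alone, no step from compound 1 to compound 3 can be read, because both results are limits and not numbers: the limit of > 100000 nM in this assay, at which 3 of the 3 values shown sit. The compounds shown leave open how strongly each inhibits growth, and whether phenyl in place of hydrogen changes that.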